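The source may hold more compounds than are shown below. What is called first, only, known or untested is meant among the compounds shown, and "the series" means these compounds.

Three compounds have been measured in a functional assay (B cells) with Mus musculus as the target; on this read-out lower numbers stand for an effect already at smaller amounts and higher numbers for an effect only at larger amounts of compound:

compound 1 `Nc1nc(O)c2c(n1)n(C1OC(CO)[C@@H](O)[C@H]1O)c(=O)n2Cc1ccc(Cl)cc1`: 14 uM
compound 2 `C=CCn1c(=O)n(Cc2ccccc2)c2nc(N)nc(O)c21`: 5 uM
compound 3 `C=CCn1c(=S)n(COCCO)c2nc(N)nc(O)c21`: 14 uM

Compound 1 and compound 3 give the same number within the usual scatter, so no order between them can be read. Compound 2 gives a lower number than compound 1, and that gap lies beyond the scatter. No two of these compounds differ in only one place, so no single structural change can be tied to a single shift in the numbers.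

Compound 4 `Cn1c(=O)n(C2OC(CO)[C@@H](O)[C@H]2O)c2nc(N)nc(O)c21` has not been measured. It differs from compound 1 in one place: hydrogen in place of 4-chlorophenyl on a saturated chain carbon bound to an aromatic nitrogen. Among the measured compounds there is no example of this change, so the expectation rests on the wide range of the three numbers seen and on the size of the group that leaves. The step is expected to be a 2.1-fold higher number from compound 1 to compound 4 (0.33 log units; beyond the scatter), toward a higher number, with a broad range. For compound 4 the expected value in this assay is 30 uM, between 8 uM and 120 uM.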

Compound 4, concentration for half-maximal effect: 10 uM
Compound 4: middle estimate off by 3.0-fold (0.48 log units), on the high side; the measured number falls inside the stated range.
By their numbers in this assay, from the lowest: compounds 2, 4, 1 and 3 (each within the scatter of the next, the first and the last beyond it).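

In this assay, putting hydrogen in place of 4-chlorophenyl on a saturated chain carbon bound to an aromatic nitrogen gives a 1.4-fold lower number from compound 1 to compound 4 (0.15 log units; within the scatter). Cut one bond further out, this is 4-chlorobenzyl to methyl, so in this pair a whole aromatic ring and its chlorine can leave without the number moving beyond the usual scatter; the earlier compounds offered no pair that could show this. Nothing at hand explains the result.

The pair does not tell how other groups would read at this place, such as an amine, a carboxylic acid or a longer chain. It also leaves open whether the same change would read the same way on a different core.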